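From a Hydroxyphenyl to an Aminophenyl Amine Substituent

A few compounds are considered here, and "the series" means these few. Any claim that something is new, unique, unknown or untested is made for them only; others in the source may bear on it.

Compound 1, structure `Fc1cccc(-c2nc(Nc3ccccc3F)c3cc(F)ccc3n2)c1`, measured value > 50000 nM.
Compound 2, structure `Oc1ccc(Nc2nc(-c3cccc(F)c3)nc3ccc(F)cc23)cc1`, measured value > 50000 nM.

In a functional assay on COLO 205 cells (Homo sapiens) for cytotoxicity, read by MTT assay, with a stated time of 48 h (on this read-out lower numbers stand for stronger inhibition and higher numbers for weaker inhibition), compound 1 gives > 50000 nM, which is a limit of the assay rather than a number. In this assay compound 2 gives > 50000 nM, again only a limit. Between them lies a step that the two limits leave unreadable from compound 1 to compound 2, whose size the two limits leave unreadable. Compound 2 therefore stands at the limit of > 50000 nM in this assay, at which 2 of the 2 values shown sit, where both measured values sit.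

Compound 3 has the structure `Nc1ccccc1Nc1nc(-c2cccc(F)c2)nc2ccc(F)cc12`. It differs from compound 2 by 2-aminophenyl in place of 4-hydroxyphenyl on a nitrogen on an aromatic ring. Among the measured compounds shown here, the only measured step concerns the same position on the shared core, but its size is unreadable, so it gives no direction and no size for the change to compound 3. The expectation is that compound 3 also sits at the limit, with an expected step of a number no higher from compound 2 to compound 3 (the limit leaves the size open) that is not readable beyond the scatter. Compound 3 is estimated at 50000 nM, with a range from 15000 nM to 150000 nM.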

Compound 3, half-maximal inhibitory concentration: > 50000 nM
Compound 3 gave a limit, no number (the forecaster's own chance of this, stated with the estimate: 75%); the middle value lies on the limit itself.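

Compound 1, compound 2 and compound 3 each give only a limit in this assay, so no step among them can be read: the limit of > 50000 nM in this assay, at which 3 of the 3 values shown sit.

The compounds shown leave open how far apart these three compounds really lie, and which group on the nitrogen, if any, would give a measurable value.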